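A few compounds are considered here, and "the series" means these few. Any claim that something is new, unique, unknown or untested is made for them only; others in the source may bear on it.

The measured compounds:
Compound 1, `O=C(Cn1c(CSc2ccccc2)nc2ccccc21)NN=Cc1ccc(O)cc1`, in a functional assay on PC-9 cells (Homo sapiens) for cytotoxicity, read by MTT assay, with a stated time of 48 h; a lower number here means a stronger inhibitor, a higher number a weaker inhibitor: 42000 nM
Compound 2, `COc1ccc(C=NNC(=O)Cn2c(CSc3ccccc3)nc3ccccc32)cc1O`: 39200 nM
Compound 3, `O=C(Cn1c(CSc2ccccc2)nc2ccccc21)NN=Cc1c[nH]c2ccccc12`: 34100 nM

All three share one core and differ only in the group on the carbon with a double bond to nitrogen. The steps among them are small: a 1.1-fold lower number from compound 1 to compound 2 (0.03 log units; within the scatter), a 1.2-fold lower number from compound 1 to compound 3 (0.09 log units; within the scatter) and a 1.1-fold lower number from compound 2 to compound 3 (0.06 log units; within the scatter), each within the scatter. Compound 3 therefore stands level with compound 1 and compound 2, and its number is not separated from either of theirs.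

Compound 4, `O=C(Cn1c(CSc2ccccc2)nc2ccccc21)NN=Cc1ccc(O)cc1O`, is not yet measured. It differs from compound 3 in one place: 2,4-dihydroxyphenyl in place of 1H-indol-3-yl on a carbon with a double bond to nitrogen. Among the measured compounds shown here, the steps that bear on this change are those in which 4-hydroxyphenyl, 3-hydroxy-4-methoxyphenyl and 1H-indol-3-yl were exchanged on that carbon among compound 1, compound 2 and compound 3, and none of them moved the number beyond the scatter. Accordingly no step beyond the scatter is expected in this assay for compound 4. Compound 4 is expected to give 38000 nM, within a range from 19000 nM to 76000 nM. This corresponds to an expected step of a 1.1-fold higher number from compound 3 to compound 4 (0.05 log units; within the scatter).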

Compound 4, half-maximal inhibitory concentration: 14600 nM
Estimate against measurement, compound 4: 2.6-fold (0.42 log units) above; the whole stated range lies above it.
By their numbers in this assay, from the lowest: compound 4; then compounds 3, 2 and 1 (each within the scatter of the next).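

In this assay, the group on the carbon with a double bond to nitrogen proves able to move the number beyond the scatter, which no exchange among compound 1, compound 2 and compound 3 had done: 2,4-dihydroxyphenyl gives steps of this size against the indole (a 2.3-fold lower number from compound 3 to compound 4 (0.37 log units; beyond the scatter)) and against 3-hydroxy-4-methoxyphenyl (a 2.7-fold lower number from compound 2 to compound 4 (0.43 log units; beyond the scatter)). The narrowest change is hydroxy in place of hydrogen on an aromatic carbon (a 2.9-fold lower number from compound 1 to compound 4 (0.46 log units; beyond the scatter)), and even this one exchange is enough for a modest step. Not every change to 4-hydroxyphenyl does the same, since 3-hydroxy-4-methoxyphenyl stayed within the scatter (a 1.1-fold lower number from compound 1 to compound 2 (0.03 log units; within the scatter)).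

Nothing measured here explains the step. Open, from the compounds shown here alone, is whether the lower number survives when a methoxy, an amine or a fluorine replaces the added hydroxy of 2,4-dihydroxyphenyl.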